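Propyl for methoxy on a biaryl amine: expected activation

This account rests on a few compounds, and the source may have more. Where it says the series, first, only, none or still open, it means among the compounds named here.

Measured compounds:
- compound 1, `Oc1ccccc1CNc1ccc(-c2ccc(C(F)(F)F)cc2)cc1`, gives "not active" (no number reported) in a functional assay on Jurkat cells (Homo sapiens) for activation, with a stated time of 24 h; on this read-out lower numbers stand for an effect already at smaller amounts and higher numbers for an effect only at larger amounts of compound
- compound 2, `COc1ccc(-c2ccc(NCc3ccccc3O)cc2)cc1`, gives 580 nM in this assay

Among the compounds with values here, compound 2 carries the only number reported in this assay; compound 1 is recorded without a number, so no step between the two can be stated. The unmeasured compound 3, `CCCc1ccc(-c2ccc(NCc3ccccc3O)cc2)cc1`, differs from compound 2 in one place: propyl in place of methoxy on an aromatic carbon. Within the data shown here, no step between measured compounds is available that would show how such a change plays out here, so the expectation rests on compound 2 alone. Compound 3 is expected to sit close to compound 2, with the step of a 1.6-fold higher number from compound 2 to compound 3 (0.19 log units; within the scatter) estimated to be small and, if anything, toward larger amounts, not clearly beyond the scatter. For compound 3 the estimated value is 900 nM, with a range from 300 nM to 3000 nM.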

Compound 3, half-maximal effective concentration: 2390 nM
Compound 3: middle estimate off by 2.7-fold (0.42 log units), on the low side, and the stated range covers the measured number.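

At the aromatic carbon para to a large group, propyl in place of methoxy gives a 4.1-fold higher number from compound 2 to compound 3 (0.61 log units; beyond the scatter) in this assay, so the group at this place does change the read-out, and the change here goes toward larger amounts of compound. Even so, the position still allows a measurable effect with an all-carbon chain: compound 3 has a number, whereas compound 1, with trifluoromethyl at this place, is recorded as "not active" (no number reported), and any step involving compound 1 cannot be read. No measurement shown accounts for the step.

The compounds shown leave open whether the shift follows the loss of the oxygen or the arrival of the longer chain. Ethyl, ethoxy or an amine at this place would bear on that question.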